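The source may hold more compounds than are shown below. What is called first, only, known or untested is meant among the compounds shown, and "the series" means these compounds.

Of the compounds shown here, three of one family have been measured for their ability to block prostaglandin D2 receptor 2 in an in vitro functional assay on HEK285-7 cells for antagonist activity at prostaglandin D2 receptor 2 (Homo sapiens), read by BRET and beta-arrestin recruitment; a lower number here means a stronger inhibitor, a higher number a weaker inhibitor. Compound 1, `O=C(O)Cc1sc(C(c2ccccc2)c2ccc(Cl)cc2)nc1-c1ccc(Cl)cc1`, gives 75 nM. Compound 2, `O=C(O)Cc1sc(C(c2ccccc2)c2ccccc2)nc1-c1ccccc1`, gives 370 nM. Compound 3, `O=C(O)Cc1sc(C(c2ccc(F)cc2)c2ccc(F)cc2)nc1-c1ccccc1`, gives 240 nM. Among these, compound 3 and compound 2 sit close together, within the usual scatter of such measurements, so neither can be called the stronger of the two. Compound 3 is further from compound 1, a gap that lies beyond the scatter, and compound 1 is the strongest inhibitor of the three.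

The next step keeps the whole of compound 3 except one ring. Compound 4, `O=C(O)Cc1sc(C(c2ccc(F)cc2)c2ccc(F)cc2)nc1-c1ccnc(N2CCCC2)c1`, carries a change that is counted as 2-(pyrrolidin-1-yl)pyridin-4-yl in place of phenyl on an aromatic carbon. Because no two of the measured compounds differ only at this position, the size and direction of this step rest on the pattern of the three numbers alone. Going by the values given here, compound 1, with 75 nM, shows that a substituted ring at this site can go together with a stronger inhibitor, but no compound shows a pyridine ring there. The step of a 1.6-fold lower number from compound 3 to compound 4 (0.20 log units; within the scatter) is therefore expected to be modest and towards a stronger inhibitor. For compound 4 the estimate is 150 nM, with a range from 40 nM to 600 nM.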

Compound 4, half-maximal inhibitory concentration: > 100000 nM
Compound 4 was reported as a limit; the forecaster's own chance of this, stated with the estimate: 3%; at least 660-fold (2.82 log units) between middle value and limit.
By their numbers in this assay, from the lowest: compound 1; then compounds 3 and 2 (each within the scatter of the next). At a limit, above all of these: compound 4.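

Going by these compounds alone, this is the first step that changes only the ring on the aromatic carbon next to the ring nitrogen, and it shows that this position does not tolerate every ring. In this assay, placing 2-(pyrrolidin-1-yl)pyridin-4-yl where phenyl stood gives an at least 410-fold higher number from compound 3 to compound 4 (2.61 log units; beyond the scatter), so a single change here can remove nearly all measurable inhibition, while the rest of the molecule stays the same. Compound 4 stands at a limit of the assay, not at a measured number: the limit of > 100000 nM in this assay, at which 1 of the 4 values shown sits.

The entering group differs from phenyl in two ways at once, with a nitrogen in the six-membered aromatic ring and a pyrrolidine ring attached to it, and this one step cannot separate the two. The compounds shown leave open whether a plain pyridin-4-yl ring, without the pyrrolidine, would keep the inhibition seen with phenyl, and whether a smaller group on that pyridine, such as a methoxy or a dimethylamino group, would do the same.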